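Amino in place of nitro: working notes

The compounds below may be only part of what the source reports. "The series", "measured", "known", "first", "only" and "open" are said of these compounds alone.

compound 1 `C=C[C@@](C)(/C=C/c1ccc(OC(=O)CCC)cc1)CCC=C(C)C` gives 50%
compound 2 `C=C[C@@](C)(/C=C/c1ccc(O)c([N+](=O)[O-])c1)CCC=C(C)C` gives 52%

In a functional assay on A549 cells (Homo sapiens) for inhibition, with a stated time of 48 h, tested at 50 uM (a lower number here means less inhibition of growth, a higher number more inhibition of growth at the concentration tested), compound 2 stands within the scatter of compound 1, so these two values do not separate. The change to compound 3 `C=C[C@@](C)(/C=C/c1ccc(O)c(N)c1)CCC=C(C)C` is amino in place of nitro on an aromatic carbon and puts amino in place of nitro on an aromatic carbon, ortho to a hydroxy group. Among the measured compounds shown here, no measured step sizes such a change, so no direction can be read from the data. The estimated change is a number 2 percentage points lower from compound 2 to compound 3 (within the scatter) and no shift beyond the scatter is expected. For compound 3 the estimate is 50% (expected range 30% to 72%).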

Compound 3, percent growth inhibition at one concentration: 41%
Estimate against measurement, compound 3: 9 percentage points above; low and high end bracket the measured number.
By their numbers in this assay, from the lowest: compounds 3, 1 and 2 (each within the scatter of the next, the first and the last beyond it).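

In this assay, among the compounds shown here, amino in place of nitro on an aromatic carbon, ortho to a hydroxy group, gives a number 11 percentage points lower from compound 2 to compound 3 (beyond the scatter), the first step that can be sized, and a modest one. This position therefore responds to the group it carries, with compound 2 retaining more growth inhibition at the concentration tested than compound 3. Nothing measured here accounts for this step.

On these data alone, it remains open whether an acetamide at this position would stand with compound 2 or with compound 3. As far as these compounds go, it also remains open whether the step would hold with a methoxy group in place of the hydroxy group.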